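Working Notes: Acetyl, Isopropyl and Butyl Analogues

The compounds below may be only part of what the source reports. "The series", "measured", "known", "first", "only" and "open" are said of these compounds alone.

compound 1 `CC(=O)c1ccc(N/N=C2\CCC(C)n3c2ncc(C(=O)O)c3=O)cc1`: 9.5 umol/kg
compound 2 `CC(C)c1ccc(N/N=C2\CCC(C)n3c2ncc(C(=O)O)c3=O)cc1`: 2.4 umol/kg

In a functional assay on the whole organism for inhibition, with Rattus norvegicus as the target (a lower number here means that less compound is needed, a higher number that more compound is needed for the effect), compound 1 gives 9.5 umol/kg and compound 2 gives 2.4 umol/kg. Compound 2 stands lowest of the two numbers measured; the step of a 4.0-fold lower number from compound 1 to compound 2 (0.60 log units; beyond the scatter) is beyond the scatter. Compound 3 `CCCCc1ccc(N/N=C2\CCC(C)n3c2ncc(C(=O)O)c3=O)cc1` is not yet measured; it differs from compound 2 by butyl in place of isopropyl on an aromatic carbon. Among the compounds with values here, the only measured step exchanges acetyl for isopropyl and does not address isopropyl against butyl, both without ring, donor or acceptor. No step beyond the scatter in this assay is therefore expected. Compound 3 is estimated at 2.5 umol/kg, range 1 umol/kg to 6 umol/kg. The expected step is a 1.0-fold higher number from compound 2 to compound 3 (0.02 log units; within the scatter).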

Compound 3, dose for 50% inhibition: 7.8 umol/kg
Compound 3: the middle estimate sits 3.1-fold (0.49 log units) below what was measured, and the stated range ends below it.
By their numbers in this assay, from the lowest: compound 2; then compounds 3 and 1 (each within the scatter of the next).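

In this assay this position, para to a large group, does not treat the two alkyl groups alike: butyl in place of isopropyl gives a 3.3-fold higher number from compound 2 to compound 3 (0.51 log units; beyond the scatter), although neither group carries a ring, donor or acceptor. Butyl in place of acetyl gives a 1.2-fold lower number from compound 1 to compound 3 (0.09 log units; within the scatter), so removing the acetyl group does not by itself lower the number. Nothing available explains the difference between isopropyl and butyl. The compounds shown leave open whether a propyl chain, a tert-butyl group or a longer chain on this carbon would track isopropyl or butyl.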